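The compounds below may be only part of what the source reports. "The series", "measured", "known", "first", "only" and "open" are said of these compounds alone.

Compound 1 `O=S(=O)(/C=C/c1ccc(Cl)c(Cl)c1)Cc1ccc(Nc2ncnc3ccccc23)cc1`: 22000 nM
Compound 2 `O=S(=O)(/C=C/c1ccc(Cl)cc1Cl)Cc1ccc(Nc2ncnc3ccccc23)cc1`: 2000 nM

In a functional assay on SK-OV-3 cells (Homo sapiens) (on this read-out lower numbers stand for stronger inhibition of growth and higher numbers for weaker inhibition of growth), compound 2 holds the lower of the two numbers, at 2000 nM. Compound 3 `O=S(=O)(/C=C/c1ccc(Cl)cc1Cl)Cc1ccc(Nc2ncnc3cc(Cl)ccc23)cc1` keeps its 2,4-dichlorophenyl group and differs by chloro in place of hydrogen on an aromatic carbon, on an aromatic carbon of the shared core. Among the compounds with values here, the only measured step, an 11-fold lower number from compound 1 to compound 2 (1.04 log units; beyond the scatter), is large but concerns the dichlorophenyl pattern, so it bears only indirectly. Within the data shown here, no measured step tests chloro at this place, so neither direction is favoured and no change beyond the scatter is expected. The expected step is a 1.3-fold lower number from compound 2 to compound 3 (0.12 log units; within the scatter). For compound 3 the estimated value is 1500 nM, with an expected range of 300 nM to 8000 nM.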

Compound 3, concentration for 50% growth inhibition: 48000 nM
Compound 3: middle estimate off by 32-fold (1.51 log units), on the low side; measured number above the stated range.
By their numbers in this assay, from the lowest: compound 2; then compound 1; then compound 3.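

In this assay, chloro in place of hydrogen on an aromatic carbon of the shared core gives a 24-fold higher number from compound 2 to compound 3 (1.38 log units; beyond the scatter), a large step beyond the scatter and towards weaker inhibition of growth. This position on the six-membered aromatic ring of carbon only is therefore not neutral, and the number responds to the core as well as to the dichlorophenyl pattern. Nothing available explains this step. From the compounds shown here alone, it remains open whether any group at this carbon weakens inhibition of growth or chloro alone does, which a methoxy group or an amine there would help separate. Also open, going by these compounds, is whether chloro has the same effect alongside the 3,4-dichlorophenyl group of compound 1.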